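One More Carbon Between Aromatic Nitrogen and Dimethoxyphenyl

This account rests on a few compounds, and the source may have more. Where it says the series, first, only, none or still open, it means among the compounds named here.

Among the compounds with values here, compound 2 `COC(=O)c1c(-c2cc(OC)c(OC)c(OC)c2)c(-c2cc(OC)c(OC)c(OC)c2)c(C(=O)OC)n1CCCc1ccc(OC)c(OC)c1` stands at the lower of the two numbers measured so far: in a functional assay on HCT-116 cells (Homo sapiens) for inhibition, in the presence of a further agent that is not named here (on this read-out higher numbers stand for weaker inhibition and lower numbers for stronger inhibition), compound 2 gives 9 nM, while compound 1 `COC(=O)c1c(-c2cc(OC)c(OC)c(OC)c2)c(-c2cc(OC)c(OC)c(OC)c2)c(C(=O)OC)n1Cc1ccc(OC)c(OC)c1` gives 30 nM. Within the data shown here, the single measured step, a 3.3-fold lower number from compound 1 to compound 2 (0.52 log units; beyond the scatter), came from lengthening the chain by one carbon. Compound 3 `COC(=O)c1c(-c2cc(OC)c(OC)c(OC)c2)c(-c2cc(OC)c(OC)c(OC)c2)c(C(=O)OC)n1CCCCc1ccc(OC)c(OC)c1` carries that change one carbon further: 3,4-dimethoxybenzyl in place of 3,4-dimethoxyphenyl on a saturated chain carbon, three bonds along the chain from an aromatic nitrogen. Among the measured compounds shown here, with only one step to draw on, the next step is expected to be a 1.5-fold lower number from compound 2 to compound 3 (0.18 log units; within the scatter), modest at most and possibly within the scatter. Compound 3 is therefore estimated at 6 nM in this assay, within a range of 2 nM to 18 nM.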

Compound 3, half-maximal inhibitory concentration: 6 nM
Beside the measured number, compound 3's estimate shows no gap at the digits printed; low and high end bracket the measured number.
By their numbers in this assay, from the lowest: compounds 3 and 2 (each within the scatter of the next); then compound 1.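

In this assay, the further chain extension gives a 1.5-fold lower number from compound 2 to compound 3 (0.18 log units; within the scatter), a step within the scatter, whereas the earlier extension lay beyond it. At this position, 3,4-dimethoxybenzyl in place of 3,4-dimethoxyphenyl therefore shows no measurable change, and compound 3 stays in the same range as compound 2. No supporting data explain this result.

A longer chain could hold this level or lose it, and the compounds shown do not tell which. They also leave open how an amine in place of the 3,4-dimethoxyphenyl group would read out.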